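A few compounds are considered here, and "the series" means these few. Any claim that something is new, unique, unknown or untested is made for them only; others in the source may bear on it.

Measured compounds in a functional assay on the whole organism (strain Swiss albino) for inhibition, with Mus musculus as the target, in the writhing test, with stated times of 30 min and 15 min, at a dose of 50 mg/kg by the oral route; on this read-out higher numbers stand for more inhibition at the one dose given (going by the name of the read-out) and lower numbers for less inhibition:
- compound 1 `O=C1N/C(=N/c2ccccc2)S/C1=C\c1ccccn1` gives 29.2%
- compound 2 `Cc1ccc(/N=C2/NC(=O)/C(=C/c3ccccn3)S2)cc1` gives 43.2%

Compound 2 stands highest of the two numbers; the nearest is compound 1, whose number is lower by a step beyond the scatter. Within the data shown here, that single step, a number 14 percentage points higher from compound 1 to compound 2 (beyond the scatter), is methyl in place of hydrogen on an aromatic carbon, and it is the only measured step.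

The next compound, compound 3 `O=C1N/C(=N/c2ccc(F)cc2)S/C1=C\c1ccccn1`, differs from compound 2 by fluoro in place of methyl on an aromatic carbon. Among the measured compounds shown here, no measured step exchanges methyl for fluoro, so nothing in the numbers speaks directly to this change. The step that bears on it, a number 14 percentage points higher from compound 1 to compound 2 (beyond the scatter), shows that a group of one heavy atom on this aromatic carbon gives a number higher than hydrogen there. Fluoro is likewise one heavy atom with no ring at the same place, so compound 3 is expected to fall between the two measured numbers, closer to compound 2, with the step of a number 6.2 percentage points lower from compound 2 to compound 3 (within the scatter) expected to stay within the scatter. Compound 3 is therefore estimated at 37%, in the range 24% to 50%.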

Compound 3, a percentage reported as inhibition, in the whole organism at one dose (the size of the read-out at that dose, not a potency): 43.2%
Estimate against measurement, compound 3: 6.2 percentage points below; low and high end bracket the measured number.
By their numbers in this assay, from the lowest: compound 1; then compounds 2 and 3 (each within the scatter of the next).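

In this assay, fluoro in place of methyl on this aromatic carbon gives no change at the digits printed from compound 2 to compound 3 (within the scatter), so the read-out does not separate these two groups at this position. Fluoro in place of hydrogen gives a number 14 percentage points higher from compound 1 to compound 3 (beyond the scatter), the same reading as a number 14 percentage points higher from compound 1 to compound 2 (beyond the scatter), so the rise over the unsubstituted compound 1 is no longer tied to methyl alone but is seen with two different groups of one heavy atom and no ring. No measured evidence bears on why the two groups read alike.

On these data alone, both groups are small and carry no hydrogen-bond donor or acceptor, so it remains open whether the number holds, rises or falls with a larger or more functional group at this place, such as trifluoromethyl, methoxy, an amine, a carboxylic acid or a longer alkyl chain. With a single dose and only two substituents beyond hydrogen, the readings also leave open how far the equality of methyl and fluoro extends to other groups, and they give no measure of potency.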